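From 4-bromophenyl to 3,5-dimethylphenyl on a sulfur

The compounds below may be only part of what the source reports. "The series", "measured", "known", "first", "only" and "open" are said of these compounds alone.

Compound 1 `CCc1ccc(SCc2ccc(C(=O)Nc3ccccc3N)cc2)cc1`: 40.7%
Compound 2 `Nc1ccccc1NC(=O)c1ccc(CSc2ccc(Br)cc2)cc1`: 9.96%

Among the measured compounds shown here, in a functional assay on HCT-116 cells (Homo sapiens) for inhibition, read by CCK-8 assay, with a stated time of 72 h, tested at 2 uM (a higher number here means more inhibition of growth at the concentration tested, a lower number less inhibition of growth), compound 2 gives 9.96%, the lower of the two numbers so far, and its only neighbour is compound 1 at 40.7%. The next compound, compound 3 `Cc1cc(C)cc(SCc2ccc(C(=O)Nc3ccccc3N)cc2)c1`, has not yet been measured. It carries 3,5-dimethylphenyl in place of 4-bromophenyl on a sulfur.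

For the measured compounds named here, one measured step bears on this change: a number 30.7 percentage points lower from compound 1 to compound 2 (beyond the scatter). That large step came with bromo in place of ethyl on an aromatic carbon. Compound 3 also lacks the bromo and carries alkyl groups instead, as compound 1 does with its ethyl at 40.7%. Going by the values given here, no measured compound has the 3,5-dimethylphenyl group, however, so the reversal may be only partial. A rise in this assay is therefore expected, somewhat smaller than the measured step, though the uncertainty is wide. The expected step is a number 20 percentage points higher from compound 2 to compound 3 (beyond the scatter). For compound 3 the estimated value is 30%, with an expected range of 12% to 52%.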

Compound 3, percent growth inhibition at one concentration: 3.22%
Compound 3: middle estimate off by 26.8 percentage points, on the high side; measured number below the stated range.
By their numbers in this assay, from the lowest: compounds 3 and 2 (each within the scatter of the next); then compound 1.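

In this assay, 3,5-dimethylphenyl in place of 4-bromophenyl on a sulfur gives a number 6.7 percentage points lower from compound 2 to compound 3 (within the scatter), so this exchange separates compound 2 and compound 3 by no more than the usual scatter. The same group in place of 4-ethylphenyl gives a number 37.5 percentage points lower from compound 1 to compound 3 (beyond the scatter), which shows that alkyl groups on this aromatic ring do not by themselves retain the growth inhibition seen with compound 1, now the only one of the three whose number stands beyond the scatter of both others. No measurement shown here explains why 4-ethylphenyl stands apart from the other two groups on the sulfur.

Compound 1 and compound 3 differ both in their alkyl groups and in where these sit on the ring, and the compounds shown cannot separate these two changes. As far as these compounds go, it remains open whether a single methyl group, a propyl chain or a methoxy group on this ring would give a number near that of compound 1 or one near those of compound 2 and compound 3.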